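A few compounds are considered here, and "the series" means these few. Any claim that something is new, unique, unknown or untested is made for them only; others in the source may bear on it.

In a functional assay on NCI-H460 cells (Homo sapiens) for antiproliferative activity, read by CCK-8 assay, with a stated time of 72 h (on this read-out higher numbers stand for weaker inhibition and lower numbers for stronger inhibition), compound 1 `CCC(C)n1cnc2c(NCc3ccc(C(=O)Nc4ccccc4N)cc3)nc(Cl)nc21` gives 4940 nM and compound 2 `Nc1ccccc1NC(=O)c1ccc(COCNc2nc(Nc3ccccc3)c3ncn(C4CCCC4)c3n2)cc1` gives 18100 nM. Compound 2 thus holds the higher of the two numbers, a gap beyond the scatter. Compound 3 `CCCCn1cnc2c(Nc3ccccc3)nc(NCOCc3ccc(C(=O)Nc4ccccc4N)cc3)nc21` differs from compound 2 in one place: butyl in place of cyclopentyl on an aromatic nitrogen. Within the data shown here, no measured step shows what such a swap does, so no shift beyond the scatter is expected in this assay, only a slightly lower number, with the estimated step of a 1.2-fold lower number from compound 2 to compound 3 (0.08 log units; within the scatter). For compound 3 the estimated value is 15000 nM, with an expected range from 6000 nM to 40000 nM.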

Compound 3, half-maximal inhibitory concentration: 8780 nM
Beside the measured number, compound 3's estimate is 1.7-fold (0.23 log units) above it; measured number inside the range.
By their numbers in this assay, from the lowest: compounds 1 and 3 (each within the scatter of the next); then compound 2.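

Replacing cyclopentyl with butyl on the aromatic nitrogen of the five-membered ring gives, in this assay, a 2.1-fold lower number from compound 2 to compound 3 (0.31 log units; beyond the scatter). This modest step shows that the group at this position affects the read-out and that a ring is not required there for activity in this assay. No measured evidence here accounts for the shift.

As far as these compounds go, whether a longer chain such as hexyl, or a chain ending in an amine, would lower the number further remains open. This single step also cannot show whether the effect would carry over to other cores.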